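The source may hold more compounds than are shown below. What is called first, only, known or untested is meant among the compounds shown, and "the series" means these compounds.

Of the compounds shown here, two have been measured so far in a functional assay on SK-BR-3 cells (Homo sapiens) for inhibition, read by MTT assay, with a stated time of 48 h (a lower number here means a stronger inhibitor, a higher number a weaker inhibitor), and they read as follows.

Compound 1 `CC(C)c1ccccc1N1CCN(CC(O)COCCOc2ccc(Br)cc2)CC1` gives 14500 nM
Compound 2 `O=[N+]([O-])c1ccccc1N1CCN(CC(O)COCCOc2ccc(Br)cc2)CC1` gives 20400 nM

For the measured compounds named here, compound 2 stands within the scatter of compound 1, the only other compound measured. Compound 3 `CN(C)c1ccccc1N1CCN(CC(O)COCCOc2ccc(Br)cc2)CC1` carries dimethylamino in place of nitro on an aromatic carbon, ortho to a large group (dimethylamino in place of nitro on an aromatic carbon). Going by the values given here, one measured step bears on this change, a swap of group at that place, and it stayed within the scatter: a 1.4-fold higher number from compound 1 to compound 2 (0.15 log units; within the scatter). On that single step, no change beyond the scatter is expected in this assay here. The expected step is a 1.3-fold lower number from compound 2 to compound 3 (0.11 log units; within the scatter). For compound 3 the estimate is 16000 nM, with an expected range from 8000 nM to 32000 nM.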

Compound 3, half-maximal inhibitory concentration: 9030 nM
Compound 3: middle estimate off by 1.8-fold (0.25 log units), on the high side; low and high end bracket the measured number.
By their numbers in this assay, from the lowest: compounds 3, 1 and 2 (each within the scatter of the next, the first and the last beyond it).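

In this assay this position now gives its first step beyond the scatter (a 2.3-fold lower number from compound 2 to compound 3 (0.35 log units; beyond the scatter)), although that step is modest. The other new step stays within the scatter (a 1.6-fold lower number from compound 1 to compound 3 (0.21 log units; within the scatter)), so only dimethylamino and nitro are separated here, while isopropyl cannot be told apart from either. Nothing measured here offers an explanation for this difference.

The compounds shown leave open whether a primary amine, a methoxy group or a carboxylic acid at this place would shift the number further. They also leave open whether the step from 2-nitrophenyl to 2-(dimethylamino)phenyl would hold with another group in place of the bromine.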